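Growing the Amide Chain from Isopropyl to tert-Butyl

This account rests on a few compounds, and the source may have more. Where it says the series, first, only, none or still open, it means among the compounds named here.

Compound 2 `CC(C)C(=O)Nc1ccc(S(=O)(=O)Oc2ccccc2I)cc1` carries an isopropylcarbonyl amide on the shared core. In a functional assay on HT-29 cells (Homo sapiens) for antiproliferative activity, read by sulforhodamine B assay, with a stated time of 48 h (a lower number here means a stronger inhibitor, a higher number a weaker inhibitor), compound 2 gives 13000 nM. For the measured compounds named here, only one other number is known, and it lies within the scatter of this one: compound 1 `CCCC(=O)Nc1ccc(S(=O)(=O)Oc2ccccc2I)cc1` bears a propyl chain on the same carbonyl carbon, and in this assay compound 1 gives 11000 nM. Going by the values given here, the single step between measured compounds, a 1.2-fold higher number from compound 1 to compound 2 (0.07 log units; within the scatter), shows that reshaping the chain from propyl to isopropyl left the number essentially where it was.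

Compound 3 `CC(C)(C)C(=O)Nc1ccc(S(=O)(=O)Oc2ccccc2I)cc1` has not yet been tested. The change from compound 2 to compound 3 is methyl in place of hydrogen on a saturated chain carbon bound to a carbonyl carbon and two saturated chain carbons, which turns the amide into a ((tert-butyl)carbonyl)amino group. Among the compounds with values here, the only step that bears on this, a 1.2-fold higher number from compound 1 to compound 2 (0.07 log units; within the scatter), was small and concerned a different reshaping of the same chain, so it is an indirect guide at best, and nothing in the numbers points to a large move. For compound 3 the expected step is a 1.1-fold higher number from compound 2 to compound 3 (0.03 log units; within the scatter), not beyond the scatter. The estimate for compound 3 in this assay is 14000 nM, with a range from 6000 nM to 35000 nM.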

Compound 3, half-maximal inhibitory concentration: 9500 nM
Estimate against measurement, compound 3: 1.5-fold (0.17 log units) above; the range from low to high includes it.
By their numbers in this assay, from the lowest: compounds 3, 1 and 2 (each within the scatter of the next).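

Adding one methyl at this saturated chain carbon, which turns isopropyl into tert-butyl, gives a 1.4-fold lower number from compound 2 to compound 3 (0.14 log units; within the scatter) in this assay and so does not separate the two groups. Comparing the unbranched chain directly with the most branched one of the set gives a 1.2-fold lower number from compound 1 to compound 3 (0.06 log units; within the scatter) and so does not separate those two either, which extends what the earlier pair showed: propyl, isopropyl and tert-butyl on this carbonyl carbon all give numbers within the scatter of one another, even though tert-butyl carries the extra methyl. No outside measurement bears on this result, so the data offer no explanation for how close these numbers lie.

On these data alone, these three compounds cover only small saturated groups on the carbonyl carbon, so it remains open whether a longer chain, an amine or a carboxylic acid placed there would move the number beyond the scatter. All three also share the rest of the structure unchanged, so they say nothing about how much the other parts of the shared core contribute to the activity seen in this assay here.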